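Aryl swap at the shared core: compound 3 to compound 4

This account rests on a few compounds, and the source may have more. Where it says the series, first, only, none or still open, it means among the compounds named here.

Measured compounds in an assay on T-REx-293 cells for inhibition of potassium channel subfamily T member 1 (Homo sapiens), read by patch clamp; on this read-out higher numbers stand for weaker inhibition and lower numbers for stronger inhibition:
- compound 1 `Cc1cccc(-c2noc([C@H](C)NC(=O)c3cc(C4CC4)n(C)n3)n2)c1`: > 30000 nM (a limit of the assay, not a number)
- compound 2 `Cc1cccc(-c2nc(C(C)NC(=O)c3cc(C(F)(F)F)nn3C)no2)c1`: 977 nM
- compound 3 `Cc1cncc(-c2noc([C@H](C)NC(=O)c3cc(C(F)(F)F)nn3C)n2)c1`: 1370 nM

Compound 1 returns only a limit in this assay, (the limit of > 30000 nM in this assay, at which 1 of the 3 values shown sits). Among the two numbers shown, compound 3 and compound 2 lie within the usual scatter of each other, so no order can be read between them; compound 3 simply sits in the same range as compound 2. Within the data shown here, no pair of measured compounds differs in a single place, so no measured step is available to calibrate the change that follows.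

Compound 4 `C[C@H](NC(=O)c1cc(C(F)(F)F)nn1C)c1nc(-c2cnn(C)c2)no1` is the untested member. It differs from compound 3 by 1-methyl-1H-pyrazol-4-yl in place of 5-methylpyridin-3-yl on an aromatic carbon of the shared core. With no measured step of this kind in hand, the expectation is a shift in this assay no larger than a modest weakening, possibly none beyond the scatter. Compound 4 is therefore estimated at 2500 nM, with a range of 900 nM to 8000 nM. The expected step from compound 3 to compound 4 is a 1.8-fold higher number from compound 3 to compound 4 (0.26 log units; within the scatter).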

Compound 4, half-maximal inhibitory concentration: 2640 nM
Compound 4: middle estimate off by 1.1-fold (0.02 log units), on the low side; the range from low to high includes it.
By their numbers in this assay, from the lowest: compounds 2, 3 and 4 (each within the scatter of the next, the first and the last beyond it). At a limit, above all of these: compound 1.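

In this assay, the position on an aromatic carbon of the shared core, between two ring nitrogen atoms, now has its first measured step: 1-methyl-1H-pyrazol-4-yl in place of 5-methylpyridin-3-yl gives a 1.9-fold higher number from compound 3 to compound 4 (0.28 log units; within the scatter). The position therefore accepts a five-membered aromatic ring with 2 hetero atoms in place of a six-membered aromatic ring with 1 hetero atom, with no change that can be told from the scatter, although this is a single exchange and no trend across aryl groups. Nothing measured here bears on the reason for this result.

On these data alone, whether this tolerance extends to a simple phenyl ring, a saturated ring such as morpholine, or an aryl group carrying a carboxylic acid or an amine remains open. Compound 1 and compound 2 each differ from compound 3 in more than one place, so the contributions of the pyrazole substituents, the orientation of the core and the stereocentre cannot be separated from these compounds.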